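The source may report more compounds than this note shows. Statements on the series, on what has been measured and on what is new or still open speak of the compounds shown alone.

In a functional assay for inhibition, with Rattus norvegicus as the target (on this read-out lower numbers stand for stronger inhibition and higher numbers for weaker inhibition), compound 2 `CCC(C)/N=c1\c(O)c(O)\c1=N/c1ccc(C#N)cc1` gives 2100 nM, the only single, exact number available for this small set. Compound 1 `C[C@@H](/N=c1\c(O)c(O)\c1=N/c1ccc(C#N)cc1)C(C)(C)C` has two entries that disagree widely, 370 nM; 24300 nM (2 entries). Compound 3 `C/N=c1\c(O)c(O)\c1=N/c1ccc(C#N)cc1` is reported as > 30000 nM, which is a limit of the assay. Within the data shown here, only one measured step bears on the change ahead: an at least 14-fold higher number from compound 2 to compound 3 (1.15 log units; beyond the scatter), a large loss on going to the smaller group. Compound 4 `Cc1ccc(C(C)/N=c2\c(O)c(O)\c2=N/c2ccc(C#N)cc2)cc1` makes the group larger instead: 4-methylphenyl in place of ethyl on a saturated chain carbon bound to a double-bonded nitrogen and a saturated chain carbon. Going by that step alone, a modest move toward stronger inhibition seems likely, though the split entries of compound 1 keep the range wide. The expected change is a 2.6-fold lower number from compound 2 to compound 4 (0.42 log units; beyond the scatter). For compound 4 the estimate is 800 nM, with an expected range of 150 nM to 5000 nM.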

Compound 4, half-maximal inhibitory concentration: > 30000 nM
Compound 4 was reported as a limit (the forecaster's own chance of this, stated with the estimate: 10%); at least 37-fold (1.57 log units) between middle value and limit.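

In this assay, a larger group on this saturated chain carbon does not help: 4-methylphenyl in place of ethyl gives an at least 14-fold higher number from compound 2 to compound 4 (1.15 log units; beyond the scatter), so growth here can cost as much inhibition as the shrinking seen in an at least 14-fold higher number from compound 2 to compound 3 (1.15 log units; beyond the scatter). The value for compound 4 is only a limit, like that of compound 3, so the full size of each loss cannot be read: the limit of > 30000 nM in this assay, at which 2 of the 4 values shown sit. Compound 1 cannot refine this picture, as its entries disagree: the several entries of compound 1 in this assay, 370 nM; 24300 nM (2 entries)

Still open, going by these compounds, is whether the aromatic ring or its methyl matters more, which phenyl at this carbon could show. Cyclohexyl could show whether a ring without aromatic character is tolerated here.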